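A few compounds are considered here, and "the series" means these few. Any claim that something is new, unique, unknown or untested is made for them only; others in the source may bear on it.

Measured in a functional assay on HOS cells (Homo sapiens) for antiproliferative activity, with a stated time of 72 h; on this read-out higher numbers stand for weaker inhibition and lower numbers for stronger inhibition:
- compound 1 `OC[C@H]1O[C@@H](n2cnc3c(NCc4ccccc4F)ncnc32)[C@H](O)[C@@H]1O`: > 166000 nM
- compound 2 `OC[C@H]1O[C@@H](n2cnc3c(NCc4ccccc4Br)ncnc32)[C@H](O)[C@@H]1O`: > 166000 nM
- compound 3 `Cc1cccc(CNc2ncnc3c2ncn3[C@@H]2O[C@H](CO)[C@@H](O)[C@H]2O)c1`: > 166000 nM

All three entries are limits, not numbers. Compound 3 stands at a limit, > 166000 nM. The whole set sits together: the limit of > 166000 nM in this assay, at which 3 of the 3 values shown sit.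

Compound 4 `COc1ccccc1CNc1ncnc2c1ncn2[C@@H]1O[C@H](CO)[C@@H](O)[C@H]1O` carries 2-methoxyphenyl in place of 3-methylphenyl on a saturated chain carbon bound to a nitrogen on an aromatic ring.

Two measured changes at this place bear on it: a step that the two limits leave unreadable from compound 1 to compound 3 and a step that the two limits leave unreadable from compound 2 to compound 3. Neither has a readable size. No step beyond the scatter is therefore expected in this assay because of the limit of > 166000 nM in this assay, at which 3 of the 3 values shown sit. The expected outcome is a step that the limit leaves unreadable from compound 3 to compound 4. For compound 4 the estimate is 200000 nM, with an expected range of 120000 nM to 400000 nM.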

Compound 4, half-maximal inhibitory concentration: > 166000 nM
Compound 4: only a limit was reported; the forecaster's own chance of this, stated with the estimate: 85%; the middle value is on the limit's open side.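

In this assay compound 4 gives a limit, > 166000 nM. No new step can be read among compound 1, compound 2, compound 3 and compound 4: the limit of > 166000 nM in this assay, at which 4 of the 4 values shown sit. The compounds shown leave open whether any change at this place gives a readable value in this assay.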